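This account rests on a few compounds, and the source may have more. Where it says the series, first, only, none or still open, it means among the compounds named here.

In a functional assay on HeLa cells (Homo sapiens) for inhibition, with a stated time of 48 h, tested at 50 uM (on this read-out lower numbers stand for less inhibition of growth and higher numbers for more inhibition of growth at the one concentration tested), compound 1 (`C=C[C@@](C)(/C=C/c1ccc(OC(=O)CCCCC)cc1)CCC=C(C)C`) gives 50%, compound 2 (`COc1ccccc1/C=C/[C@@](C)(/C=C/c1ccc(O)cc1)CCC=C(C)C`) gives 50%, and compound 3 (`COc1ccc(/C=C/[C@@](C)(/C=C/c2ccc(O)cc2)CCC=C(C)C)cc1`) gives 20%, the lowest of the three. Compound 4 (`COc1ccc(/C=C/[C@@](C)(/C=C/c2ccc(O)cc2)CCC=C(C)C)cc1C=O`) differs from compound 3 in one place: formyl in place of hydrogen on an aromatic carbon. The new formyl sits ortho to a methoxy group. Among the measured compounds shown here, only one measured step involves the ring that carries this methoxy group: with 4-methoxyphenyl in place of 2-methoxyphenyl, the data show a number 30 percentage points lower from compound 2 to compound 3 (beyond the scatter). For the measured compounds named here, no measured compound carries a formyl group, so the direction is uncertain, but a smaller upward step is the best guess. The expected change is a number 10 percentage points higher from compound 3 to compound 4 (within the scatter). For compound 4 the estimated value is 30%, with an expected range from 12% to 50%.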

Compound 4, percent growth inhibition at one concentration: 31%
Estimate against measurement, compound 4: 1 percentage points below; the measured number falls inside the stated range.
By their numbers in this assay, from the lowest: compound 3; then compound 4; then compounds 1 and 2 (each within the scatter of the next).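

In this assay, the step of a number 11 percentage points higher from compound 3 to compound 4 (beyond the scatter) is a modest one, and it comes from adding a formyl group ortho to a methoxy group. Among the compounds shown here, earlier, the only measured change on this ring was the choice between 2-methoxyphenyl and 4-methoxyphenyl, whereas here a new group is added while the 4-methoxyphenyl arrangement is kept. Nothing available explains this step.

Going by these compounds, whether an amine, a carboxylic acid or a longer chain at this place would give a similar number stays open. So does whether formyl would act the same way on the 2-methoxyphenyl ring of compound 2.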